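Amino in place of chloro: compound 3 to compound 4

The source may hold more compounds than are shown below. What is called first, only, known or untested is meant among the compounds shown, and "the series" means these compounds.

Of the compounds shown here, three have been read in an ADME assay on PBMC cells (Homo sapiens) for cytotoxicity, with a stated time of 5 days (a lower number here means a stronger inhibitor, a higher number a weaker inhibitor), so far. Compound 1 `CC(C)(CO)Nc1nc(N)nc2c1ncn2[C@H]1C[C@H](N=[N+]=[N-])[C@@H](CO)O1` gives > 100000 nM as a limit of the assay. Compound 2 `[N-]=[N+]=N[C@H]1C[C@H](n2cnc3c(NCCCCCO)nc(N)nc32)O[C@@H]1CO` gives > 100000 nM as a limit too. For the measured compounds named here, compound 3 `[N-]=[N+]=N[C@H]1C[C@H](n2cnc3c(NC4CC4)nc(Cl)nc32)O[C@@H]1CO` gives 35300 nM as the only actual number in the set. The other two compounds stand at the limit of > 100000 nM in this assay, at which 2 of the 3 values shown sit, and so offer no number for comparison.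

Compound 4 `[N-]=[N+]=N[C@H]1C[C@H](n2cnc3c(NC4CC4)nc(N)nc32)O[C@@H]1CO` differs from compound 3 by a single change, amino in place of chloro on an aromatic carbon on an aromatic carbon between two ring nitrogen atoms. Going by the values given here, the one measured step, a step that the two limits leave unreadable from compound 1 to compound 2, concerns the group on the ring nitrogen substituent and not this carbon, so no measured step sizes the change directly. Compound 1 and compound 2 both carry amino at this place, though they also differ from compound 3 in the group on nitrogen, and both sit at the limit of > 100000 nM in this assay, at which 2 of the 3 values shown sit, in the same assay. That weak evidence favours a shift towards the higher, weaker end of this assay rather than none. The expected move is a 2.4-fold higher number from compound 3 to compound 4 (0.38 log units; beyond the scatter) as an estimate only. Compound 4 is estimated at 85000 nM with an expected range of 40000 nM to 100000 nM in this assay, and a reading reported only as a limit would be no surprise.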

Compound 4, half-maximal inhibitory concentration: > 100000 nM
Compound 4: no number, only a limit; the forecaster's own chance of this, stated with the estimate: 55%; at least 1.1-fold (0.07 log units) between middle value and limit.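

In this assay this carbon between two ring nitrogen atoms now has a direct reading: with the cyclopropylamino group held fixed, amino in place of chloro gives an at least 2.8-fold higher number from compound 3 to compound 4 (0.45 log units; beyond the scatter). That size is only a lower bound on the change, since compound 4 gives > 100000 nM, which is a limit of the assay and not a number. Of the compounds shown, only compound 3 with chloro reaches a number, while compound 1, compound 2 and compound 4, all with amino on this carbon, share one limit, so the pairing of amino with the limit now holds across three different groups on the nitrogen: the limit of > 100000 nM in this assay, at which 3 of the 4 values shown sit.

The steps among compound 1, compound 2 and compound 4 cannot be read, which leaves the groups on that nitrogen unranked while amino stands on this carbon. Also open, as far as these compounds go, is how a fluoro, methyl or methoxy group on this carbon would read in this assay, and whether chloro would give a number alongside 5-hydroxypentyl or 1-(hydroxymethyl)-1-methylethyl on the nitrogen.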